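Furan-2-yl amide after three limit readings

The compounds below may be only part of what the source reports. "The series", "measured", "known", "first", "only" and "open" are said of these compounds alone.

Three amides on a shared core have been tested in a functional assay on NCI-H460 cells (Homo sapiens) for antiproliferative activity; a higher number here means a weaker inhibitor, a lower number a stronger inhibitor. Compound 1 (`COc1ccc(S(=O)(=O)Oc2ccccc2NC(=O)c2ccc3ncccc3c2)cc1`) gives > 10000 nM, a limit and not a number. Compound 2 (`COc1ccc(S(=O)(=O)Oc2ccccc2NC(=O)c2ccnc3ccccc23)cc1`) gives > 10000 nM, also a limit. Compound 3 (`COc1ccc(S(=O)(=O)Oc2ccccc2NC(=O)c2ccc(N(C)C)cc2)cc1`) gives > 10000 nM, again a limit. Compound 3 therefore has no measured position within the series, which stands at the limit of > 10000 nM in this assay, at which 3 of the 3 values shown sit.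

Compound 4 (`COc1ccc(S(=O)(=O)Oc2ccccc2NC(=O)c2ccco2)cc1`) carries furan-2-yl in place of 4-(dimethylamino)phenyl on a carbonyl carbon.

The measured steps bearing on this change alter the same place. They are a step that the two limits leave unreadable from compound 1 to compound 2, a step that the two limits leave unreadable from compound 1 to compound 3 and a step that the two limits leave unreadable from compound 2 to compound 3. None has a readable size, so none supplies a size or direction for the new change. Quinolin-6-yl, quinolin-4-yl and 4-(dimethylamino)phenyl have all left this assay at its limit, so the working expectation is that furan-2-yl will do the same. The expected change is a step that the limit leaves unreadable from compound 3 to compound 4, with no direction supported by the data. For compound 4 the estimated value is 12000 nM, with an expected range of 3000 nM to 30000 nM.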

Compound 4, half-maximal inhibitory concentration: 24 nM
The estimate for compound 4 lay 500-fold (2.70 log units) above the measured number, and the stated range ends above it.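

In this assay, this position on the carbonyl carbon proves able to carry strong activity on the shared core, which the earlier amides could not show, as the steps among compound 1, compound 2 and compound 3 cannot be read. Furan-2-yl gives an at least 410-fold lower number from compound 3 to compound 4 (2.61 log units; beyond the scatter), and the same change gives an at least 410-fold lower number from compound 2 to compound 4 (2.61 log units; beyond the scatter) and an at least 410-fold lower number from compound 1 to compound 4 (2.61 log units; beyond the scatter). The position is also selective among the groups shown, with a five-membered aromatic ring with 1 hetero atom giving a measurable number, while quinolin-6-yl, quinolin-4-yl and 4-(dimethylamino)phenyl do not, so an amide at this place is not enough by itself: the limit of > 10000 nM in this assay, at which 3 of the 4 values shown sit.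

The compounds shown do not separate the contribution of the ring oxygen from that of the smaller five-membered ring, and thiophen-2-yl, furan-3-yl or plain phenyl on the same carbonyl carbon would address that question. They also leave open whether the furan-2-yl amide keeps its activity when the methoxy group elsewhere on the shared core gives way to another group, such as a chlorine atom or an amine.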